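Swapping Butyl for Vinyl on an Amide Carbonyl

The source may report more compounds than this note shows. Statements on the series, on what has been measured and on what is new or still open speak of the compounds shown alone.

Of the compounds shown here, three sharing a common core have been tested in a functional assay on KYSE-450 cells (Homo sapiens) for inhibition, read by MTT assay, with a stated time of 48 h; a higher number here means a weaker inhibitor, a lower number a stronger inhibitor. Compound 1 `COc1ccc(CNc2cc(OC)c(OC)c(OC)c2)cc1[N+](=O)[O-]` gives 16800 nM. Compound 3 `C/C=C/C(=O)N(Cc1ccc(OC)c(C)c1)c1cc(OC)c(OC)c(OC)c1` gives 32900 nM. Compound 2 `CCCCC(=O)N(Cc1ccc(OC)c(O)c1)c1cc(OC)c(OC)c(OC)c1` gives 300 nM, the lowest of the three numbers and therefore the strongest inhibitor among them, well separated from both of the others. Compound 4 `C=CC(=O)N(Cc1ccc(OC)c(O)c1)c1cc(OC)c(OC)c(OC)c1` has not yet been measured. It differs from compound 2 in a single place: vinyl in place of butyl on a carbonyl carbon. Among the compounds with values here, no measured pair shows this exact change on its own, so there is no direct guide to its effect. Compound 3 carries a different chain on its carbonyl carbon, but it also differs from compound 2 elsewhere, so its high number cannot be attributed to the chain alone. In the absence of a clean comparison, the step of a 1.3-fold higher number from compound 2 to compound 4 (0.12 log units; within the scatter) is expected to be modest and could fall in either direction. Compound 4 is estimated to give 400 nM, within a range from 100 nM to 2000 nM.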

Compound 4, half-maximal inhibitory concentration: 160 nM
The estimate for compound 4 lay 2.5-fold (0.40 log units) above the measured number; measured number inside the range.
By their numbers in this assay, from the lowest: compounds 4 and 2 (each within the scatter of the next); then compounds 1 and 3 (each within the scatter of the next).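

In this assay, within the data shown here, the step of a 1.9-fold lower number from compound 2 to compound 4 (0.27 log units; within the scatter) gives the first clean reading of this position, since only the group on the carbonyl carbon changes. The step lies within the scatter, so vinyl and butyl cannot be told apart here. With the rest of the molecule held fixed, this position therefore accepts a group of 2 heavy atoms with a double bond as well as one of 4 heavy atoms without a double bond.

Still open, as far as these compounds go, is whether a longer chain, a phenyl ring or an amine on the carbonyl carbon would stay in this range, and whether a saturated ethyl group would read like vinyl, which would separate chain length from the double bond. Nothing available explains why vinyl and butyl read alike.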